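A few compounds are considered here, and "the series" means these few. Any claim that something is new, unique, unknown or untested is made for them only; others in the source may bear on it.

In a functional assay on cells (leukaemia cell line, Homo sapiens) for inhibition, read by sulforhodamine B assay, with a stated time of 48 h (a higher number here means a weaker inhibitor of growth, a lower number a stronger inhibitor of growth), compound 3 (`Cc1cc(NS(=O)(=O)c2ccc(-c3cnc(C4CC4)o3)cc2)ccc1Cl`) gives 216 nM, within the scatter of compound 2 (`O=S(=O)(Nc1ccc(F)c(Cl)c1)c1ccc(-c2cnc(C3CC3)o2)cc1`) at 260 nM and of compound 1 (`O=S(=O)(Nc1ccc(Cl)c(Cl)c1)c1ccc(-c2cnc(C3CC3)o2)cc1`) at 416 nM. Compound 4 (`O=S(=O)(Nc1ccc(Br)c(Cl)c1)c1ccc(-c2cnc(C3CC3)o2)cc1`) is next, with the change (4-bromo-3-chlorophenyl in place of 4-chloro-3-methylphenyl on a sulfonamide nitrogen), that is, 4-bromo-3-chlorophenyl in place of 4-chloro-3-methylphenyl on a sulfonamide nitrogen. Going by the values given here, three measured steps bear on it: a 1.6-fold lower number from compound 1 to compound 2 (0.20 log units; within the scatter), a 1.9-fold lower number from compound 1 to compound 3 (0.28 log units; within the scatter) and a 1.2-fold lower number from compound 2 to compound 3 (0.08 log units; within the scatter). Among the compounds with values here, all three stay within the scatter, though no bromo compound has been measured yet. No step beyond the scatter is therefore expected in this assay. The expected change is a 1.7-fold higher number from compound 3 to compound 4 (0.22 log units; within the scatter). Compound 4 is estimated at 360 nM, with an expected range of 180 nM to 720 nM.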

Compound 4, concentration for 50% growth inhibition: 491 nM
The estimate for compound 4 lay 1.4-fold (0.13 log units) below the measured number, within the range that was stated.
By their numbers in this assay, from the lowest: compounds 3, 2, 1 and 4 (each within the scatter of the next, the first and the last beyond it).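

In this assay, going by these compounds alone, the change from 4-chloro-3-methylphenyl to 4-bromo-3-chlorophenyl gives the first step beyond the scatter at this sulfonamide nitrogen, though only a modest one (a 2.3-fold higher number from compound 3 to compound 4 (0.36 log units; beyond the scatter)). Bromo in place of a single halogen does not separate the compounds, with both (a 1.9-fold higher number from compound 2 to compound 4 (0.28 log units; within the scatter)) and (a 1.2-fold higher number from compound 1 to compound 4 (0.07 log units; within the scatter)) within the scatter. No measurement shown accounts for the larger step.

Going by these compounds, whether an amine or a methoxy group in place of the bromo would keep the number in this range remains open, as does any effect of a carboxylic acid on this aromatic ring.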